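Swapping a Methoxy for a Hydroxy on a Melanoma Cell Assay

The source may report more compounds than this note shows. Statements on the series, on what has been measured and on what is new or still open speak of the compounds shown alone.

Measured so far in a functional assay on UACC-62 cells (Homo sapiens) for inhibition, read by sulforhodamine B assay, with a stated time of 48 h; on this read-out lower numbers stand for higher toxicity in this test and higher numbers for lower toxicity in this test:
- compound 1, `COc1cc(C)cc(-c2nn(CC#N)cc2-c2ccc(-c3cccc(C(C)=O)c3)nc2)c1`: > 100000 nM
- compound 2, `Cc1cc(O)cc(-c2nn(CC#N)cc2-c2ccnc(-c3ccc(Oc4ccccc4)cc3)c2)c1`: 44400 nM
- compound 3, `COc1cc(C)cc(-c2nn(CC#N)cc2-c2ccnc(-c3ccc(N(C)C)cc3)c2)c1`: > 100000 nM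

The values for compound 1 and compound 3 are limits of the assay, not numbers. Compound 3 stands at the limit of > 100000 nM in this assay, at which 2 of the 3 values shown sit. Compound 2 gives a measured number, but it differs from compound 3 in more than one place, so its value only shows that a hydroxy-bearing analogue can register within range.

Compound 4, `Cc1cc(O)cc(-c2nn(CC#N)cc2-c2ccnc(-c3ccc(N(C)C)cc3)c2)c1`, differs from compound 3 by hydrogen in place of methyl on an oxygen on an aromatic ring. A small step towards lower numbers in this assay is expected, possibly within scatter. Compound 4 is estimated at 70000 nM, between 30000 nM and 150000 nM. This expectation corresponds to an at least 1.4-fold lower number from compound 3 to compound 4 (0.15 log units; that floor lies within the scatter).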

Compound 4, concentration lethal to 50% of the cells: 72100 nM
Compound 4: the middle estimate sits 1.0-fold (0.01 log units) below what was measured; the range from low to high includes it.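

Changing methoxy to hydroxy on the 3-methoxy-5-methylphenyl ring brings the reading within range in this assay, and the change is an at least 1.3-fold lower number from compound 3 to compound 4 (0.14 log units; that floor lies within the scatter). Compound 3 gives only a limit, so the true size of that step cannot be told: the limit of > 100000 nM in this assay, at which 2 of the 4 values shown sit. With the hydroxy in place, dimethylamino and phenoxy on the aromatic carbon are not told apart, as the comparison shows a 1.6-fold higher number from compound 2 to compound 4 (0.21 log units; within the scatter).

Going by these compounds, what remains open is how a longer chain on this oxygen, such as ethoxy, would read. On these data alone, an amine in place of the hydroxy is equally open.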